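Working notes: from compound 3 to compound 4

A few compounds are considered here, and "the series" means these few. Any claim that something is new, unique, unknown or untested is made for them only; others in the source may bear on it.

In an ADME assay on microsomes from liver (Mus musculus) for metabolic stability, using NADPH, with a stated time of 10 min (a lower number here means that less of the compound is left, a higher number that more of the compound is left), compound 1 `CN(C)[C@H]1CCN(c2cccc3c2C[C@H](CN(C)[C@H]2CCCc4cccnc42)NC3)C1` gives 18.5% as its reading. Compound 2 `CN1CC[C@H]2CN(c3cccc4c3C[C@H](CN(C)[C@H]3CCCc5cccnc53)NC4)C[C@H]21` gives 24% as its reading. Compound 3 `CN(C[C@H]1Cc2c(cccc2N2C[C@H]3CCN(C)[C@H]3C2)CN1)[C@H]1CCCc2cccnc21` has no number, its result being "not determined" (no result reported) in this assay so the nearest anchor rests on the fact that compounds 2 and 3 differ only in the configuration as drawn and not on a reading of its own. The move to compound 4 `CN1C[C@@H]2CN(c3cccc4c3C[C@H](CN(C)[C@H]3CCCc5cccnc53)NC4)C[C@@H]2C1` keeps the same atoms, joined differently: a group of 9 heavy atoms (7 carbon, 2 nitrogen; 2 five-membered non-aromatic rings with 1 hetero atom each) in place of a group of 9 heavy atoms (7 carbon, 2 nitrogen; 2 five-membered non-aromatic rings with 1 hetero atom each), on an aromatic carbon is the whole change. Within the data shown here, the only measured step that bears on it is a number 5.5 percentage points higher from compound 1 to compound 2 (within the scatter) and this exchange of groups on an aromatic carbon stays small. No step beyond the scatter is therefore expected in this assay for this change. For compound 4 the estimated value is 23% with an expected range from 11% to 38% as the working figure.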

Compound 4, percent of the compound remaining: 32.9%
Beside the measured number, compound 4's estimate is 9.9 percentage points below it, and the stated range covers the measured number.
By their numbers in this assay, from the lowest: compounds 1, 2 and 4 (each within the scatter of the next, the first and the last beyond it).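

In this assay the group with the same atoms, joined differently, on the aromatic carbon shows a number 8.9 percentage points higher from compound 2 to compound 4 (within the scatter), so the way the two five-membered rings are joined is not separated from the scatter. Against the group of compound 1, with one five-membered ring, a number 14.4 percentage points higher from compound 1 to compound 4 (beyond the scatter) is the one step at this position beyond the scatter, unlike a number 5.5 percentage points higher from compound 1 to compound 2 (within the scatter).

Compound 3 has no reading, so its step to compound 4 cannot be read, and its nearest anchor is compound 2: the fact that compounds 2 and 3 differ only in the configuration as drawn. On these data alone, whether an open-chain diamine or a morpholine on this aromatic carbon would read differently stays open.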